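The source may report more compounds than this note shows. Statements on the series, on what has been measured and on what is new or still open speak of the compounds shown alone.

The series begins with compound 1 `C[Se]c1nc(N)c2ccccc2n1` and compound 2 `Nc1nc([SeH])nc2ncccc12`, both tested in a functional assay on HT-29 cells (Homo sapiens) for cytotoxicity, read by MTT assay, with a stated time of 72 h; on this read-out lower numbers stand for stronger inhibition of growth and higher numbers for weaker inhibition of growth. In this assay compound 1 gives 27600 nM, and compound 2 gives 36300 nM, two numbers that sit close to each other. Compound 3 `C[Se]c1nc([Se]C)c2cccnc2n1` was also examined, yet in this assay compound 3 gives "not determined" (no result reported), so it stands nowhere on the numbers shown and offers no anchor of its own.

The step from compound 3 leads to compound 4 `C[Se]c1nc(N)c2cccnc2n1`. The change is one nitrogen atom in place of a group of 2 heavy atoms (1 carbon, 1 selenium; no ring), on an aromatic carbon: the amino group enters where the group of two heavy atoms, one carbon and one selenium, leaves, on an aromatic carbon of the six-membered aromatic ring. With no number for compound 3, the size of this step in this assay cannot be judged from a measured pair, and no direction beyond the scatter can be claimed for it.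

What remains is the resemblance of compound 4 to compound 1 and compound 2. Because compound 1 gives 27600 nM and compound 2 gives 36300 nM, compound 4 is expected to give about 30000 nM, within a range from 8000 nM to 100000 nM.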

Compound 4, concentration for 50% growth inhibition: 44100 nM
Compound 4: the middle estimate sits 1.5-fold (0.17 log units) below what was measured; the measured number falls inside the stated range.
By their numbers in this assay, from the lowest: compounds 1, 2 and 4 (each within the scatter of the next).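

In this assay, a methyl in place of the hydrogen on the selenium gives a 1.2-fold higher number from compound 2 to compound 4 (0.08 log units; within the scatter) and so stays within the scatter. Among these compounds, for this position, the read-out therefore does not separate the hydrogen from the methyl, which the earlier compounds could not show on their own. The step that brings in amino for the group of 2 heavy atoms cannot be read, as compound 3 has no number, and no measurement at hand accounts for the outcome of the methyl step.

From the compounds shown here alone, whether a longer chain such as ethyl or propyl on the selenium would leave the scatter remains open. Going by these compounds, it is also open how a carboxylic acid or a benzyl group would fare at that same place.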